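Ring Swaps on the Sulfonamide Side Chain: Lipophilicity Notes

The compounds below may be only part of what the source reports. "The series", "measured", "known", "first", "only" and "open" are said of these compounds alone.

Compound 1 `CC1(C)C[C@H](CN([C@H](CCC(F)(F)F)C(N)=O)S(=O)(=O)c2ccc(Cl)cc2)O1` is the reference point of this small set. Among the measured compounds shown here, in a physicochemical assay for lipophilicity, read by HPLC, measured as octanol-water partition, at pH 7.4 (on this read-out higher numbers stand for higher lipophilicity and lower numbers for lower lipophilicity), compound 1 gives 3.8, the highest of the three numbers so far, though its margins over the other two stay within the scatter. Compound 2 `NC(=O)[C@@H](CCC(F)(F)F)N(C[C@@H]1CCCOC1)S(=O)(=O)c1ccc(Cl)cc1` gives 3.7 in this assay, and compound 3 `NC(=O)[C@@H](CCC(F)(F)F)N(CC1CCOCC1)S(=O)(=O)c1ccc(Cl)cc1` gives 3.5. The two steps from the reference are a number 0.10 log units lower from compound 1 to compound 2 (within the scatter) and a number 0.30 log units lower from compound 1 to compound 3 (within the scatter); between the two oxane isomers the step is a number 0.20 log units lower from compound 2 to compound 3 (within the scatter). None of these exchanges of the saturated ring on the chain carbon bound to the sulfonamide nitrogen has moved the number beyond the scatter.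

Compound 4 `NC(=O)[C@@H](CCC(F)(F)F)N(C[C@@H]1CCOC1)S(=O)(=O)c1ccc(Cl)cc1` has not yet been measured. Its difference from compound 1 is oxolan-3-yl in place of 4,4-dimethyloxetan-2-yl on a saturated chain carbon bound to a sulfonamide nitrogen. The steps to compound 2 and compound 3 are the ones that bear on it, since each also replaces the 4,4-dimethyloxetan-2-yl group with a saturated oxygen ring at the same place, and both were small. Compound 4 carries the smallest entering group of the three by the count given with the change, so a somewhat larger downward step than either is expected, a number 0.50 log units lower from compound 1 to compound 4 (beyond the scatter), likely still near the edge of the scatter. Compound 4 is therefore estimated at 3.3, with a range from 2.9 to 3.7.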

Compound 4, distribution coefficient: 2.8
The estimate for compound 4 lay 0.50 log units above the measured number, and the stated range ends above it.
By their numbers in this assay, from the lowest: compound 4; then compounds 3, 2 and 1 (each within the scatter of the next).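

In this assay, among the compounds shown here, the oxolan-3-yl group on a saturated chain carbon bound to a sulfonamide nitrogen gives the only steps in this set that lie beyond the scatter: a number 1.00 log units lower from compound 1 to compound 4 (beyond the scatter), a number 0.90 log units lower from compound 2 to compound 4 (beyond the scatter) and a number 0.70 log units lower from compound 3 to compound 4 (beyond the scatter). This place is therefore not indifferent to the saturated oxygen ring it carries: compounds 1, 2 and 3 remain within the scatter of one another, while the five-membered ring of compound 4 separates it from all three, including the direct exchange of oxan-3-yl for oxolan-3-yl. Nothing measured here accounts for the separation of compound 4 from the others.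

The compounds shown leave open whether the separation follows the five-membered ring itself or the place of its oxygen, and cyclopentyl and oxolan-2-yl at the same carbon would bear on that question. They also leave open how the oxolan-3-yl group with the opposite configuration at its stereocentre would read in this assay.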